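From Phenoxy to Chloro: An Expected Step

A few compounds are considered here, and "the series" means these few. Any claim that something is new, unique, unknown or untested is made for them only; others in the source may bear on it.

Measured in a physicochemical assay for solubility, at pH 7.4; a higher number here means a more soluble compound, a lower number a less soluble compound:
Compound 1 `CCOC(=O)c1c(-c2cccc(OC)c2)[nH]c2cc(OC)ccc2c1=O`: 74000 nM
Compound 2 `CCOC(=O)c1c(-c2cccc(OCC)c2)[nH]c2cc(OC)ccc2c1=O`: 8700 nM
Compound 3 `CCOC(=O)c1c(-c2cccc(Oc3ccccc3)c2)[nH]c2cc(OC)ccc2c1=O`: 4300 nM

Compound 3, at 4300 nM, has the lowest number of the three, and compound 2 is its nearest neighbour. The next molecule, compound 4 `CCOC(=O)c1c(-c2cccc(Cl)c2)[nH]c2cc(OC)ccc2c1=O`, carries chloro in place of phenoxy on an aromatic carbon.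

Among the compounds with values here, no measured step makes this exact swap, so the evidence is indirect. The three measured steps all change the group on the oxygen: an 8.5-fold lower number from compound 1 to compound 2 (0.93 log units; beyond the scatter) was modest, a 2.0-fold lower number from compound 2 to compound 3 (0.31 log units; beyond the scatter) was also modest, and a 17-fold lower number from compound 1 to compound 3 (1.24 log units; beyond the scatter) was large. Across these compounds the number fell as that group went from methyl to ethyl to phenyl, and none of the three goes against this. Chloro has no oxygen and lies outside that series, so the trend can only be read loosely and in reverse as phenoxy leaves. A modest rise in this assay therefore seems likely. The expected change is a 3.5-fold higher number from compound 3 to compound 4 (0.54 log units; beyond the scatter). For compound 4 the estimated value is 15000 nM, with an expected range from 4000 nM to 50000 nM.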

Compound 4, solubility: 58000 nM
For compound 4 the middle estimate is 3.9-fold (0.59 log units) below the measured one; measured number above the stated range.
By their numbers in this assay, from the lowest: compound 3; then compound 2; then compounds 4 and 1 (each within the scatter of the next).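

In this assay, chloro in place of phenoxy on this aromatic carbon gives a 13-fold higher number from compound 3 to compound 4 (1.13 log units; beyond the scatter) and chloro in place of ethoxy gives a 6.7-fold higher number from compound 2 to compound 4 (0.82 log units; beyond the scatter), so a single chlorine atom with no oxygen brings the number well above those of the two compounds with the larger ether groups. Chloro in place of methoxy gives a 1.3-fold lower number from compound 1 to compound 4 (0.11 log units; within the scatter), a difference within the scatter, so this assay cannot separate chloro from methoxy at this position, and an oxygen on this carbon is clearly not needed for a number at the level of compound 1. No measurement shown here explains why these groups differ.

Chloro is the only group without an oxygen at this position, so it remains open whether an amine, a nitrile or a longer carbon chain placed here would keep the number at the level of compound 4. All four compounds also share the same core and ester, which leaves open whether these steps would hold if a carboxylic acid replaced that ester.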